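Moving the Chlorine on the Sulfonyl Ring

The source may hold more compounds than are shown below. What is called first, only, known or untested is meant among the compounds shown, and "the series" means these compounds.

Three compounds sharing one core differ only in the ring attached to the sulfonyl sulfur. In an assay on MDA-MB-231 cells for binding affinity to C-X-C chemokine receptor type 4 (Homo sapiens), read by microscopy, with stated times of 10 min and 30 min (on this read-out higher numbers stand for an effect only at larger amounts of compound and lower numbers for an effect already at smaller amounts), compound 1 `O=C(NCc1ccc(CNS(=O)(=O)c2ccc(Cl)cc2)cc1)c1ccc(CNc2ncccn2)cc1` gives 100 nM. Compound 2 `O=C(NCc1ccc(CNS(=O)(=O)c2cccc(Cl)c2)cc1)c1ccc(CNc2ncccn2)cc1` gives 1 nM, the lowest of the three numbers, and compound 3 `Cc1ccccc1S(=O)(=O)NCc1ccc(CNC(=O)c2ccc(CNc3ncccn3)cc2)cc1` gives 10 nM. The measured steps are a 100-fold lower number from compound 1 to compound 2 (2.00 log units; beyond the scatter) and a 10-fold higher number from compound 2 to compound 3 (1.00 log units; beyond the scatter), so the kind and the placement of the group on this ring move the read-out well beyond the scatter.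

Compound 4 `O=C(NCc1ccc(CNS(=O)(=O)c2ccccc2Cl)cc1)c1ccc(CNc2ncccn2)cc1` is not yet measured. It differs from compound 2 in one place: 2-chlorophenyl in place of 3-chlorophenyl on a sulfonyl sulfur. The step that bears most directly on this change is a 10-fold higher number from compound 2 to compound 3 (1.00 log units; beyond the scatter), where 2-methylphenyl replaced 3-chlorophenyl on the sulfonyl sulfur, and a 100-fold lower number from compound 1 to compound 2 (2.00 log units; beyond the scatter) shows that the placement of the chlorine alone can matter a great deal. A step of modest size toward higher numbers is therefore expected, a 10-fold higher number from compound 2 to compound 4 (1.00 log units; beyond the scatter). Compound 4 is estimated at 10 nM, with a range from 2 nM to 50 nM.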

Compound 4, effective concentration (reported as EC, without a stated level of effect): 1000 nM
Estimate against measurement, compound 4: 100-fold (2.00 log units) below, and the stated range ends below it.
By their numbers in this assay, from the lowest: compound 2; then compound 3; then compound 1; then compound 4.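

Moving the chlorine alone, with the same atoms joined differently, spans far more than the earlier compounds did: a 1000-fold higher number from compound 2 to compound 4 (3.00 log units; beyond the scatter) in this assay and a 10-fold higher number from compound 1 to compound 4 (1.00 log units; beyond the scatter) give compound 4 the highest number of the four, while compound 2 keeps the lowest. The kind of group also counts at this placement, since chloro in place of methyl on an aromatic carbon gives a 100-fold higher number from compound 3 to compound 4 (2.00 log units; beyond the scatter) and the 2-chlorophenyl and 2-methylphenyl rings therefore do not behave alike here. Nothing in the data shown explains why the placement or the kind of group has such an effect.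

From the compounds shown here alone, it remains open whether the low number of compound 2 belongs to chlorine itself or would also appear with a methyl, a methoxy group or a fluorine on the ring. An amine or a carboxylic acid in place of the chlorine, or a plain phenyl ring with no added group, would test how much of the read-out depends on that chlorine at all.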